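Indole in Place of Fluorophenyl at the Carbonyl Carbon

The source may report more compounds than this note shows. Statements on the series, on what has been measured and on what is new or still open speak of the compounds shown alone.

Measured so far in a functional assay on NCI-H1299 cells (Homo sapiens) for antiproliferative activity, read by XTT assay, with a stated time of 72 h; a lower number here means a stronger inhibitor, a higher number a weaker inhibitor:
Compound 1, `COc1ccc(-c2cc3ccccc3nc2/C=C/C(=O)c2ccc(F)cc2)cc1`: 820 nM
Compound 2, `COc1ccc(-c2cc3ccccc3nc2/C=C/C(=O)c2ccc(O)cc2)cc1`: 8970 nM
Compound 3, `COc1ccc(-c2cc3ccccc3nc2/C=C/C(=O)c2cnc(N)nc2C)cc1`: > 10000 nM, which is a limit of the assay and not a number.

Compound 1 gives the lowest of the two numbers; its nearest neighbour is compound 2, with an 11-fold higher number from compound 1 to compound 2 (1.04 log units; beyond the scatter). Compound 4, `COc1ccc(-c2cc3ccccc3nc2/C=C/C(=O)c2c[nH]c3ccccc23)cc1`, departs from compound 1 by 1H-indol-3-yl in place of 4-fluorophenyl on a carbonyl carbon. Going by the values given here, two measured steps bear on this. One is an at least 12-fold higher number from compound 1 to compound 3 (1.08 log units; beyond the scatter), where the 4-fluorophenyl on the carbonyl carbon also gave way to a heteroaromatic group carrying a hydrogen-bond donor, and compound 3 then sat at the limit of > 10000 nM in this assay, at which 1 of the 3 values shown sits. The other is an 11-fold higher number from compound 1 to compound 2 (1.04 log units; beyond the scatter), where a hydrogen-bond donor entered on the ring that sits on the carbonyl carbon. Both were large rises, so a rise for compound 4 in this assay is expected as well. Among the compounds with values here, the entering 1H-indol-3-yl keeps a six-membered aromatic ring of carbon only, a feature that no measured step tests on its own. Compound 4 is therefore estimated at 5000 nM, within 1500 nM to 15000 nM, an expected step of a 6.1-fold higher number from compound 1 to compound 4 (0.79 log units; beyond the scatter).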

Compound 4, half-maximal inhibitory concentration: > 10000 nM
Compound 4 ended at the assay's limit; the forecaster's own chance of this, stated with the estimate: 30%; middle value at least 2.0-fold (0.30 log units) away from the limit.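

In this assay, 1H-indol-3-yl on the carbonyl carbon gives an at least 12-fold higher number from compound 1 to compound 4 (1.08 log units; beyond the scatter), so keeping a six-membered aromatic ring of carbon only is not enough to retain the activity seen with 4-fluorophenyl. Set against the 4-hydroxyphenyl group, the change gives an at least 1.1-fold higher number from compound 2 to compound 4 (0.04 log units; that floor lies within the scatter), so no order can be drawn between these two groups. Compound 4 carries a limit and not a number, as does compound 3, so the step between them cannot be read: the limit of > 10000 nM in this assay, at which 2 of the 4 values shown sit.

Open, on these data alone, is whether the loss follows the hydrogen-bond donor shared by compound 2, compound 3 and compound 4, which compound 1 lacks, or some other feature of these groups. A comparison of 1-methyl-1H-indol-3-yl with 1H-indol-3-yl, or of 4-methoxyphenyl with 4-hydroxyphenyl, would address that question at this position.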